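Adding a Fluorine Next to a Biphenyl Amine

The source may hold more compounds than are shown below. What is called first, only, known or untested is meant among the compounds shown, and "the series" means these compounds.

Compound 1 `O=[N+]([O-])c1ccc(NCc2ccccc2O)cc1` is recorded in a functional assay on Jurkat cells (Homo sapiens) for activation, with a stated time of 24 h (a higher number here means that more compound is needed for the effect, a lower number that less compound is needed), as "not active" (no number reported). Going by the values given here, compound 2 `Oc1ccccc1CNc1ccc(-c2ccccc2)cc1` gives 1820 nM in this assay, and it is the only compound here with a numerical result, so there is nothing to rank it against. Compound 3 `Oc1ccccc1CNc1ccc(-c2ccccc2)cc1F` differs from compound 2 by fluoro in place of hydrogen on an aromatic carbon. Among the compounds with values here, with no earlier step of this kind to draw on, the change is expected to stay within the usual scatter, in no clear direction. Compound 3 is expected to give about 1500 nM, with a range from 600 nM to 4500 nM. The step of a 1.2-fold lower number from compound 2 to compound 3 (0.08 log units; within the scatter) is therefore estimated to be small.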

Compound 3, half-maximal effective concentration: 5350 nM
For compound 3 the middle estimate is 3.6-fold (0.55 log units) below the measured one; the whole stated range lies below it.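

In this assay, fluoro in place of hydrogen on this aromatic carbon is not a neutral swap: the step is a 2.9-fold higher number from compound 2 to compound 3 (0.47 log units; beyond the scatter) and so more compound is needed for the effect. Even this single added atom, ortho to a group of 9 heavy atoms and meta to a phenyl group, thus changes the result for the shared core. Nothing measured here accounts for the shift.

Going by these compounds, whether a methoxy group or an amine at this same carbon would shift the number in the same direction stays open. So does whether fluoro elsewhere on the core would have a similar effect.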